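Moving the methoxy group from compound 3 to compound 4

This account rests on a few compounds, and the source may have more. Where it says the series, first, only, none or still open, it means among the compounds named here.

In an ADME assay on cells (Macrophage, Homo sapiens) for inhibition (on this read-out higher numbers stand for lower toxicity in this test and lower numbers for higher toxicity in this test), compound 3 (`COc1cccc(Cc2nnc(Cn3nnc4ccccc43)o2)c1`) gives > 100000 nM as a limit and not a number. Compound 1 (`c1ccc(Cc2nnc(Cn3nnc4ccccc43)o2)cc1`) gives > 100000 nM as a limit too. Compound 2 (`Clc1cccc(Cc2nnc(Cn3nnc4ccccc43)o2)c1`) gives > 100000 nM as a limit as well. Taken together, that is the limit of > 100000 nM in this assay, at which 3 of the 3 values shown sit, and no exact value so far.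

Compound 4 (`COc1ccccc1Cc1nnc(Cn2nnc3ccccc32)o1`) has the same atoms as compound 3, joined differently, with 2-methoxyphenyl in place of 3-methoxyphenyl on a saturated chain carbon bound to an aromatic carbon.

The closest guides are a step that the two limits leave unreadable from compound 1 to compound 3 and a step that the two limits leave unreadable from compound 2 to compound 3 and, in the same series, a step that the two limits leave unreadable from compound 1 to compound 2 for the chloro change. None of these has a size that can be read, so they offer no measured effect to carry over to the new compound. The most they show is that all three compounds share the same limit. In this assay no step beyond the usual scatter is therefore expected, and no direction can be given. The expected change is a number no higher from compound 3 to compound 4 (the limit leaves the size open) in this estimate. The estimated value for compound 4 is 100000 nM within an expected range from 40000 nM to 200000 nM and the likeliest report is again only a limit.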

Compound 4, half-maximal cytotoxic concentration: > 100000 nM
Compound 4 ended at the assay's limit (the forecaster's own chance of this, stated with the estimate: 85%); the middle value sits exactly at the limit.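

In this assay compound 4 gives > 100000 nM, a limit and not a number. Compound 1, compound 2 and compound 3 also stop at a limit, so no step from any of them to compound 4 can be read: the limit of > 100000 nM in this assay, at which 4 of the 4 values shown sit.

The compounds shown leave open what exact value any of them would give, and whether swapping 3-methoxyphenyl for 2-methoxyphenyl changes the read-out at all.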